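This account rests on a few compounds, and the source may have more. Where it says the series, first, only, none or still open, it means among the compounds named here.

In a functional assay on MDA-MB-231 cells (Homo sapiens) for inhibition, read by MTT assay, with a stated time of 72 h (on this read-out higher numbers stand for weaker inhibition and lower numbers for stronger inhibition), compound 1 (`CC(C)(C)n1cc2c(n1)C(=O)CC1(CCN(C(=O)c3cc(-c4ccccc4Cl)nc4ccccc34)CC1)O2`) gives > 10000 nM, which is a limit and not a number. Compound 2 (`CC(C)(C)n1cc2c(n1)C(=O)CC1(CCN(C(=O)c3cc(-c4ccc(F)cc4)nc4ccccc34)CC1)O2`) gives > 10000 nM, also a limit. Compound 3 (`CC(C)(C)n1cc2c(n1)C(=O)CC1(CCN(C(=O)c3cc(-c4ccccn4)nc4ccccc34)CC1)O2`) gives 8100 nM, a true number, though still weak. Compound 4 (`CC(C)(C)n1cc2c(n1)C(=O)CC1(CCN(C(=O)c3cc(-c4ccncc4)nc4ccccc34)CC1)O2`) differs from compound 1 in one place: pyridin-4-yl in place of 2-chlorophenyl on an aromatic carbon. The closest guides are the two steps to a pyridin-2-yl group, an at least 1.2-fold lower number from compound 1 to compound 3 (0.09 log units; that floor lies within the scatter) and an at least 1.2-fold lower number from compound 2 to compound 3 (0.09 log units; that floor lies within the scatter). The step between the two phenyl groups, a step that the two limits leave unreadable from compound 1 to compound 2, adds nothing. A small move to lower numbers, or none beyond the scatter, is therefore expected in this assay, and a result at the limit of > 10000 nM in this assay, at which 2 of the 3 values shown sit, remains possible. The expected change is an at least 1.1-fold lower number from compound 1 to compound 4 (0.04 log units; that floor lies within the scatter). For compound 4 the estimated value is 9000 nM, within an expected range of 4500 nM to 15000 nM.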

Compound 4, half-maximal inhibitory concentration: 1650 nM
Compound 4: the middle estimate sits 5.5-fold (0.74 log units) above what was measured, outside the stated range (below it).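

For the compounds shown here, at this position, where the ring nitrogen sits clearly matters: in this assay, pyridin-4-yl in place of pyridin-2-yl gives a 4.9-fold lower number from compound 3 to compound 4 (0.69 log units; beyond the scatter), a difference the earlier compounds could not show. Pyridin-4-yl also gives a lower number than either phenyl group, with an at least 6.0-fold lower number from compound 1 to compound 4 (0.78 log units; beyond the scatter) and an at least 6.0-fold lower number from compound 2 to compound 4 (0.78 log units; beyond the scatter). Compound 1 and compound 2 each rest on a limit, so these two sizes are only floors: the limit of > 10000 nM in this assay, at which 2 of the 4 values shown sit.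

On these data alone, how pyridin-3-yl, or a pyridin-4-yl carrying an amine, would read remains open. The difference between the two pyridines is measured. These data do not explain it.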